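Swapping acetyl for dimethylamino on a cell-killing scaffold

A few compounds are considered here, and "the series" means these few. Any claim that something is new, unique, unknown or untested is made for them only; others in the source may bear on it.

Three compounds have been measured:
- compound 1, `COc1cc(C)cc(-c2c(-c3ccnc(-c4ccc(C(C)=O)cc4)c3)cnn2CC#N)c1`: 11%
- compound 2, `COc1cc(C)cc(-c2nn(CC#N)cc2-c2ccc(-c3cccc(C(C)=O)c3)nc2)c1`: -14%
- compound 3, `Cc1cc(O)cc(-c2nn(CC#N)cc2-c2ccnc(-c3ccc(Oc4ccccc4)cc3)c2)c1`: -52%

In a functional assay on NCI/ADR-RES cells (Homo sapiens) for cytotoxicity, read by sulforhodamine B assay, with a stated time of 48 h, tested at 10 uM (a lower number here means a stronger effect, a higher number a weaker effect of the compound at the concentration tested), compound 1 gives 11%, the highest of the three numbers, meaning the weakest effect on cell growth at the tested concentration. Compound 2 lies lower by a margin beyond the scatter, and compound 3 lies lowest of all. Compound 4, `COc1cc(C)cc(-c2c(-c3ccnc(-c4ccc(N(C)C)cc4)c3)cnn2CC#N)c1`, has not been measured. It differs from compound 1 in one place: dimethylamino in place of acetyl on an aromatic carbon. For the measured compounds named here, no measured pair shows this exact change, so its effect is unknown from the data. The step is expected to be small, within the scatter, with the number for compound 4 staying near that of compound 1: a number 6 percentage points lower from compound 1 to compound 4 (within the scatter). For compound 4 the estimate is 5%, with a range from -20% to 30%.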

Compound 4, a percentage reported as activity, at one concentration (the size of the read-out at that concentration, not a potency): 3%
Compound 4: middle estimate off by 2 percentage points, on the high side; measured number inside the range.
By their numbers in this assay, from the lowest: compound 3; then compound 2; then compounds 4 and 1 (each within the scatter of the next).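

In this assay, putting dimethylamino in place of acetyl on the 4-acetylphenyl group gives a number 8 percentage points lower from compound 1 to compound 4 (within the scatter). This position, para to a large group, therefore takes either group with no difference that stands out from ordinary repeat variation at this single concentration. No available evidence explains why the two groups read alike.

As far as these compounds go, whether a carboxylic acid or a longer amine chain at this position would shift the read-out remains open. So does whether the same swap would behave alike on the core of compound 2.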